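Three inactive triazole analogues and a trimethylphenyl successor

The source may hold more compounds than are shown below. What is called first, only, known or untested is meant among the compounds shown, and "the series" means these compounds.

Compound 1 `N#CC1=C(N)Oc2c(N)cc3nc4ccccc4nc3c2C12C(=O)N(Cc1cnnn1-c1ccc(F)cc1)c1ccccc12` gives > 50000 nM in a functional assay on HCT-116 cells (Homo sapiens) for antiproliferative activity, read by MTT assay, with a stated time of 48 h; a lower number here means a stronger inhibitor, a higher number a weaker inhibitor; this is a limit of the assay.
Compound 2 `N#CC1=C(N)Oc2c(N)cc3nc4ccccc4nc3c2C12C(=O)N(Cc1cnnn1-c1ccc(Cl)cc1Cl)c1ccccc12` gives > 50000 nM in this assay; this too is a limit.
Compound 3 `N#CC1=C(N)Oc2c(N)cc3nc4ccccc4nc3c2C12C(=O)N(Cc1cnnn1-c1ccc(F)c(Cl)c1)c1ccccc12` gives > 50000 nM in this assay; again a limit, not a number.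

Among the compounds with values here, every value measured so far is therefore the same limit, a point summed up by the limit of > 50000 nM in this assay, at which 3 of the 3 values shown sit. The steps between the measured compounds cannot be sized: a step that the two limits leave unreadable from compound 1 to compound 2, a step that the two limits leave unreadable from compound 1 to compound 3 and a step that the two limits leave unreadable from compound 2 to compound 3 all stay hidden behind the limits. Compound 3 accordingly stands nowhere in particular among the numbers shown, since there are no numbers, only three identical limits.

Compound 4 `Cc1cc(C)c(-n2nncc2CN2C(=O)C3(C(C#N)=C(N)Oc4c(N)cc5nc6ccccc6nc5c43)c3ccccc32)c(C)c1` differs from compound 3 in one place: 2,4,6-trimethylphenyl in place of 3-chloro-4-fluorophenyl on an aromatic nitrogen. Within the data shown here, none of the measured steps gives a readable size, so no direction can be taken from them; they only show that changing the aryl group on the triazole nitrogen has so far left every compound at the limit. The expectation is that compound 4 also sits at the limit, with a step that the limit leaves unreadable from compound 3 to compound 4 no step beyond the scatter. The estimate for compound 4 in this assay is 70000 nM, ranging from 30000 nM to 200000 nM.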

Compound 4, half-maximal inhibitory concentration: > 50000 nM
Compound 4 ended at the assay's limit (the forecaster's own chance of this, stated with the estimate: 85%); the middle value lies beyond the limit too.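

Compound 4 gives only a limit, as do compound 1, compound 2 and compound 3, so no step among these four compounds can be read: the limit of > 50000 nM in this assay, at which 4 of the 4 values shown sit.

The compounds shown leave open how far apart these four truly lie in this assay, and whether any other group on that aromatic nitrogen would give a readable number.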